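Swapping the aryl ketone group of compound 2

The source may report more compounds than this note shows. Statements on the series, on what has been measured and on what is new or still open speak of the compounds shown alone.

Of the compounds shown here, three have been measured in a functional assay on DU-145 cells (Homo sapiens) for inhibition, read by trypan blue exclusion, with a stated time of 96 h; a lower number here means a stronger inhibitor of growth, a higher number a weaker inhibitor of growth. There, compound 1 `Cc1ccc(S/C(=C/c2ccc(Br)cc2)C(=O)c2ccc(Cl)cc2)cc1` gives 25000 nM, compound 3 `O=C(/C(=C\c1ccc(O)c([N+](=O)[O-])c1)SCc1ccc(Cl)cc1)c1ccc(Cl)cc1` gives 10000 nM, and compound 2 `O=C(/C(=C\c1ccc([N+](=O)[O-])c(O)c1)SCc1ccc(Br)cc1)c1ccc([N+](=O)[O-])c(Cl)c1` gives 1000 nM, the lowest number of the three and beyond the scatter from both others. Compound 4 `O=C(O)c1ccc(C(=O)/C(=C\c2ccc([N+](=O)[O-])c(O)c2)SCc2ccc(Br)cc2)cc1` remains unmeasured; it carries 4-carboxyphenyl in place of 3-chloro-4-nitrophenyl on a carbonyl carbon. Among the measured compounds shown here, no measured pair isolates this change. Only compound 2 holds 3-chloro-4-nitrophenyl, and compound 3, without it, stands at 10000 nM. A rise beyond the scatter in this assay is therefore expected, estimated as a 5.0-fold higher number from compound 2 to compound 4 (0.70 log units; beyond the scatter). For compound 4 the expected value is 5000 nM, with an estimated range from 1500 nM to 20000 nM.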

Compound 4, concentration for 50% growth inhibition: 10000 nM
For compound 4 the middle estimate is 2.0-fold (0.30 log units) below the measured one; the measured number falls inside the stated range.
By their numbers in this assay, from the lowest: compound 2; then compounds 3 and 4 (each within the scatter of the next); then compound 1.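

In this assay, among the compounds shown here, the first step that isolates this position is a 10-fold higher number from compound 2 to compound 4 (1.00 log units; beyond the scatter) with 4-carboxyphenyl in place of 3-chloro-4-nitrophenyl on a carbonyl carbon. For the compounds shown here, the earlier compounds differed from one another in more than one place, so only this pair ties a change beyond the scatter to this position alone. Nothing at hand offers an explanation for the rise.

Still open, as far as these compounds go, is whether the chlorine or the nitro group of 3-chloro-4-nitrophenyl matters more for the lower number of compound 2. From the compounds shown here alone, how a methyl ester or an amine at this place would compare also remains unknown.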